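From trifluoromethyl to methyl at the assay limit

This account rests on a few compounds, and the source may have more. Where it says the series, first, only, none or still open, it means among the compounds named here.

Compound 1 (`COc1ccc(Br)cc1Cn1c(C(=O)NCC(C)(C)CO)cc2cc(C#N)ccc21`) – < 6 mL.min-1.g-1
Compound 2 (`Cc1ccc(C(F)(F)F)cc1Cn1c(C(=O)NCC(C)(C)CO)cc2cc(C#N)ccc21`) – < 6 mL.min-1.g-1

In an in vitro ADME assay on microsomes from Gut (Homo sapiens) for metabolic stability, using NADPH (a higher number here means faster removal of the compound, a lower number slower removal), compound 2 stands at < 6 mL.min-1.g-1 as a limit and not a number. Compound 1 also reads < 6 mL.min-1.g-1 as a limit. This leaves the limit of < 6 mL.min-1.g-1 in this assay, at which 2 of the 2 values shown sit, as all that is known so far.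

Compound 3 (`Cc1ccc(C)c(Cn2c(C(=O)NCC(C)(C)CO)cc3cc(C#N)ccc32)c1`) differs from compound 2 in having methyl in place of trifluoromethyl on an aromatic carbon. Going by the values given here, no measured step exists to go by, so in this assay no step beyond the usual scatter is expected. The expected step is a step that the limit leaves unreadable from compound 2 to compound 3 and no larger. Compound 3 is estimated at 5 mL.min-1.g-1 with an expected range from 3 mL.min-1.g-1 to 10 mL.min-1.g-1.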

Compound 3, intrinsic clearance in microsomes: < 6 mL.min-1.g-1
Compound 3: a limit, no number; the forecaster's own chance of this, stated with the estimate: 75%; the middle value does not contradict the limit.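

No step among compound 1, compound 2 and compound 3 can be read in this assay, as all three values are limits and not numbers: the limit of < 6 mL.min-1.g-1 in this assay, at which 3 of the 3 values shown sit.

The compounds shown leave open how fast each one is actually removed, and whether the changes between them alter that rate at all.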